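A few compounds are considered here, and "the series" means these few. Any claim that something is new, unique, unknown or untested is made for them only; others in the source may bear on it.

Measured compounds:
compound 1 `COc1ccc(-c2cc3cc(C)ccc3c(-c3cccc(O)c3)n2)cc1OC` with 370 nM in a functional assay on HCT-15 cells (Homo sapiens) for cytotoxicity, read by CCK-8 assay and cell counting, with a stated time of 72 h; on this read-out lower numbers stand for stronger inhibition and higher numbers for weaker inhibition
compound 2 `COc1cccc(-c2nc(-c3ccc(OC)c(OC)c3)cc3cc(C)ccc23)c1` with 1840 nM in this assay
compound 3 `COc1ccc(-c2cc3cc(C)ccc3c(-c3ccc(O)cc3)n2)cc1OC` with 2520 nM in this assay

Compound 3 gives the highest number of the three in this assay. Its nearest neighbour is compound 2, whose value lies within the usual scatter of that of compound 3, so the two cannot be told apart. Against compound 1 the gap is real: a 6.8-fold higher number from compound 1 to compound 3 (0.83 log units; beyond the scatter).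

Compound 4 `COc1ccc(-c2nc(-c3ccc(OC)c(OC)c3)cc3cc(C)ccc23)cc1` differs from compound 3 by methyl in place of hydrogen on an oxygen on an aromatic ring. For the measured compounds named here, one measured step bears directly on this change: the same methylation of the hydroxy group, there on the 3-hydroxyphenyl, gave a 5.0-fold higher number from compound 1 to compound 2 (0.70 log units; beyond the scatter). On that basis a weakening of similar size is expected for compound 4 in this assay, although with compound 3 already at the weak end of the set, the step may come out smaller than it did from compound 1 to compound 2.

The step expected from compound 3 to compound 4 is therefore a 3.2-fold higher number from compound 3 to compound 4 (0.50 log units; beyond the scatter). For compound 4 the estimated value in this assay is 8000 nM, expected to fall between 3000 nM and 25000 nM.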

Compound 4, half-maximal inhibitory concentration: 28700 nM
For compound 4 the middle estimate is 3.6-fold (0.55 log units) below the measured one, and the stated range ends below it.
By their numbers in this assay, from the lowest: compound 1; then compounds 2 and 3 (each within the scatter of the next); then compound 4.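

Methylating the hydroxy group raises the number again, with an 11-fold higher number from compound 3 to compound 4 (1.06 log units; beyond the scatter), so in this assay the loss no longer rests on a single pair and holds for the 4-hydroxyphenyl as well as the 3-hydroxyphenyl: the same change on two cores in this assay, a 5.0-fold higher number (0.70 log units; beyond the scatter) from compound 1 to compound 2 and an 11-fold higher number (1.06 log units; beyond the scatter) from compound 3 to compound 4, 2.3-fold (0.36 log units) apart, within the scatter of two such steps. The place of the group on the ring also proves to matter among the methylated compounds, a difference the earlier values could not show, since compound 2 and compound 3 lay within the scatter of each other; 4-methoxyphenyl in place of 3-methoxyphenyl gives a 16-fold higher number from compound 2 to compound 4 (1.19 log units; beyond the scatter). Combining the two changes gives the widest gap in the set, a 78-fold higher number from compound 1 to compound 4 (1.89 log units; beyond the scatter), and compound 4 is the weakest of the four, with its steps to all the others beyond the scatter.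

The compounds shown leave open whether an amine or a carboxylic acid in place of the hydroxy group would keep the number near that of compound 1. They also leave open whether the methylation would cost as much if the methyl group on the shared core were replaced by a longer chain.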